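From 2-chlorophenyl to 4-chloro-3-(trifluoromethyl)phenyl

This account rests on a few compounds, and the source may have more. Where it says the series, first, only, none or still open, it means among the compounds named here.

Compound 2 `O=C1Nc2ccccc2/C1=C/c1ccc(-c2cn(-c3ccccc3Cl)nn2)cc1` reads > 20000 nM in an ADME assay on HUVEC cells (Homo sapiens) for inhibition, read by CCK-8 assay, with a stated time of 24 h, in the presence of a further agent that is not named here (a higher number here means a weaker inhibitor, a lower number a stronger inhibitor), which is a limit and not a number. Compound 3 `N#Cc1ccc(-n2cc(-c3ccc(C=C4C(=O)Nc5ccccc54)cc3)nn2)cc1` reads > 20000 nM, also a limit. Within the data shown here, compound 1 `Cc1cccc(-n2cc(-c3ccc(/C=C4\C(=O)Nc5ccccc54)cc3)nn2)c1` gives 13700 nM in this assay, the only actual number so far.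

Compound 4 `O=C1Nc2ccccc2/C1=C/c1ccc(-c2cn(-c3ccc(Cl)c(C(F)(F)F)c3)nn2)cc1` carries 4-chloro-3-(trifluoromethyl)phenyl in place of 2-chlorophenyl on an aromatic nitrogen of the five-membered aromatic ring, with the rest of compound 2 unchanged: 4-chloro-3-(trifluoromethyl)phenyl in place of 2-chlorophenyl on an aromatic nitrogen.

Among the measured compounds shown here, one measured step bears on this change, a swap at the same place: an at least 1.4-fold higher number from compound 1 to compound 2 (0.16 log units; that floor lies within the scatter). Its size is known only as a floor. Beyond that step, the series offers only (the limit of > 20000 nM in this assay, at which 2 of the 3 values shown sit). Neither gives grounds for a large move in this assay, and any movement is expected toward a lower number.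

The expected change is an at least 1.2-fold lower number from compound 2 to compound 4 (0.09 log units; that floor lies within the scatter), which is no step beyond the scatter. For compound 4 the estimate is 16000 nM, with an expected range from 6000 nM to 30000 nM.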

Compound 4, half-maximal inhibitory concentration: > 20000 nM
Compound 4 gave a limit, no number; the forecaster's own chance of this, stated with the estimate: 50%; middle value at least 1.2-fold (0.09 log units) away from the limit.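

In this assay compound 4 reads > 20000 nM, which is a limit and not a number. Against the one actual number in the series, the change gives an at least 1.4-fold higher number from compound 1 to compound 4 (0.16 log units; that floor lies within the scatter), so even with 4-chloro-3-(trifluoromethyl)phenyl on this aromatic nitrogen, no separation beyond the scatter is shown, and the step from 2-chlorophenyl cannot be read, as both ends are limits. This position now holds a further group that gives no number in this assay: the limit of > 20000 nM in this assay, at which 3 of the 4 values shown sit.

As far as these compounds go, how compound 2, compound 3 and compound 4 rank among themselves remains open, as does whether any group at this position can give a number well clear of the limit. Also open, from the compounds shown here alone, is what a phenyl ring bearing an amine or a carboxylic acid would read here.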